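Swapping the aryl group on a shared core

The compounds below may be only part of what the source reports. "The series", "measured", "known", "first", "only" and "open" are said of these compounds alone.

Measured so far in a functional assay on MCF7 cells (Homo sapiens) for cytotoxicity, read by MTT assay, with a stated time of 96 h (on this read-out lower numbers stand for stronger inhibition and higher numbers for weaker inhibition), are these compounds:
- compound 1 `COc1cc(C(=O)c2cn(-c3ccccc3)cc2-c2ccc(N)cc2)cc(OC)c1OC` gives 9 nM
- compound 2 `COc1cc(C(=O)c2cn(-c3ccccc3)cc2-c2cccc([N+](=O)[O-])c2)cc(OC)c1OC` gives 50 nM

Compound 2 (50 nM) holds the higher of the two numbers, which makes it the weaker of this pair. Compound 3 `COc1ccc(Br)cc1-c1cn(-c2ccccc2)cc1C(=O)c1cc(OC)c(OC)c(OC)c1` has not yet been measured, and its change from compound 2 is 5-bromo-2-methoxyphenyl in place of 3-nitrophenyl on an aromatic carbon in the form of 5-bromo-2-methoxyphenyl in place of 3-nitrophenyl on an aromatic carbon. Within the data shown here, only one measured step bears on this swap. That step a 5.6-fold higher number from compound 1 to compound 2 (0.74 log units; beyond the scatter) is modest, and it also exchanges one substituted phenyl for another. Among the measured compounds shown here, no measured compound carries the entering group, so the direction in this assay stays open. The expected step of a 1.7-fold lower number from compound 2 to compound 3 (0.22 log units; within the scatter) stays within the scatter, so no real change is forecast. Compound 3 is estimated at 30 nM with 6 nM to 150 nM as the expected range.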

Compound 3, half-maximal inhibitory concentration: 2200 nM
Compound 3: middle estimate off by 73-fold (1.87 log units), on the low side; measured number outside the range, above it.
By their numbers in this assay, from the lowest: compound 1; then compound 2; then compound 3.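

In this assay this aromatic carbon of the shared core proves far less tolerant than the first pair suggested: 5-bromo-2-methoxyphenyl brings a 44-fold higher number from compound 2 to compound 3 (1.64 log units; beyond the scatter) when it replaces 3-nitrophenyl and a 240-fold higher number from compound 1 to compound 3 (2.39 log units; beyond the scatter) when it replaces 4-aminophenyl. Both steps are large, whereas the earlier exchange between substituted phenyls was modest, so the choice of aryl group here can move the number much further than that step showed. The leaving 3-nitrophenyl and the entering group hold the same number of heavy atoms, so that count does not separate them, and nothing available accounts for the size of these steps.

Going by these compounds, the entering group carries bromine and methoxy together, so the share of each in this rise stays open. On these data alone, how a hydroxyl group or a carboxylic acid on this phenyl would read out also remains unknown.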